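Isoquinolinyl to quinazolinyl ether in an inhibitor series

The source may hold more compounds than are shown below. What is called first, only, known or untested is meant among the compounds shown, and "the series" means these compounds.

Compound 1, `CC(C)[C@H](NC(=O)COc1cccc2ccccc12)C(=O)N[C@@H](CC(=O)O)C(=O)CSc1nnnn1C`, gives in a functional assay on Jurkat cells (Homo sapiens) for inhibition (on this read-out lower numbers stand for stronger inhibition and higher numbers for weaker inhibition), only a limit, > 200000 nM.
Compound 2, `CC(C)[C@H](NC(=O)COc1cccc2ccccc12)C(=O)N[C@@H](CC(=O)O)C(=O)COc1ccncn1`, gives in this assay only a limit, > 200000 nM.
Compound 3, `CC(C)[C@H](NC(=O)COc1cccc2ccccc12)C(=O)N[C@@H](CC(=O)O)C(=O)COc1cc2ccccc2cn1`, gives in this assay only a limit, > 200000 nM.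

None of the three measured compounds has a read number in this assay; every value shown is a limit, as the limit of > 200000 nM in this assay, at which 3 of the 3 values shown sit, records. The steps among them are therefore unreadable: a step that the two limits leave unreadable from compound 1 to compound 2, a step that the two limits leave unreadable from compound 1 to compound 3 and a step that the two limits leave unreadable from compound 2 to compound 3. Compound 3 stands where the other two stand, at the limit, with nothing to rank it against them.

Compound 4, `CC(C)[C@H](NC(=O)COc1cccc2ccccc12)C(=O)N[C@@H](CC(=O)O)C(=O)COc1ncnc2ccccc12`, differs from compound 3 in one place: quinazolin-4-yl in place of isoquinolin-3-yl on an oxygen on a saturated carbon. The measured step between the two ring ethers of compound 2 and compound 3 bears most directly on this change, and it is unreadable, as are the two steps from compound 1. No readable step exists from which a direction or size could be taken, so no shift beyond the scatter is expected, and the most likely outcome for compound 4 is again a limit. Compound 4 is estimated at 200000 nM, within 60000 nM to 1000000 nM, which is the expected step of a number no higher from compound 3 to compound 4 (the limit leaves the size open).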

Compound 4, half-maximal inhibitory concentration: > 200000 nM
Compound 4: no number, only a limit (the forecaster's own chance of this, stated with the estimate: 85%); the middle value sits exactly at the limit.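

Compound 4 gives only a limit, as do compound 1, compound 2 and compound 3, so none of the steps among these four compounds can be read: the limit of > 200000 nM in this assay, at which 4 of the 4 values shown sit. The compounds shown leave open whether any of these groups on the shared core differs from another in this assay, and by how much.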